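A few compounds are considered here, and "the series" means these few. Any claim that something is new, unique, unknown or untested is made for them only; others in the source may bear on it.

Working notes on the series, all read in a functional assay on BHK-21 cells (Mesocricetus auratus) for cytotoxicity, read by MTT assay; on this read-out lower numbers stand for higher toxicity in this test and higher numbers for lower toxicity in this test. Going by the values given here, compound 3 `O=C(c1ccccc1)N1N=C(c2ccccc2)CC1c1ccc(Cl)cc1` gives 250000 nM, the only actual number among the values so far. Compound 1 `O=C(c1ccccc1)N1N=C(c2cccs2)CC1c1ccc(Cl)cc1` gives > 300000 nM, which is a limit and not a number. Compound 2 `O=C(c1ccccc1)N1N=C(c2ccc(Br)s2)CC1c1ccc(Cl)cc1` gives > 300000 nM, again a limit. The rest of the picture is the limit of > 300000 nM in this assay, at which 2 of the 3 values shown sit.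

The next compound is compound 4 `CC(C)(C)C1=NN(C(=O)c2ccccc2)C(c2ccc(Cl)cc2)C1`, with the change tert-butyl in place of phenyl on a carbon with a double bond to nitrogen. Among the compounds with values here, two measured steps touch this same place, an at least 1.2-fold lower number from compound 1 to compound 3 (0.07 log units; that floor lies within the scatter) and an at least 1.2-fold lower number from compound 2 to compound 3 (0.07 log units; that floor lies within the scatter). Both are floors only, and neither shows a change beyond the scatter. The step elsewhere in the thiophene pair, a step that the two limits leave unreadable from compound 1 to compound 2, adds no size. Within the data shown here, no compound measured so far carries a non-aromatic group at this place, so the change to tert-butyl is an extrapolation, and the width of the range reflects that. Among the measured compounds shown here, with those two steps from compound 1 and compound 2 as the only guide, no step beyond the scatter is expected in this assay, and a second reading at the limit would not surprise. The estimated step is a 1.1-fold higher number from compound 3 to compound 4 (0.03 log units; within the scatter). Compound 4 is expected at 270000 nM, with an estimated range of 120000 nM to 550000 nM.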

Compound 4, half-maximal cytotoxic concentration: 65000 nM
Compound 4: the middle estimate sits 4.2-fold (0.62 log units) above what was measured; measured number outside the range, below it.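

In this assay this position now shows a single change that lies beyond the scatter, a 3.8-fold lower number from compound 3 to compound 4 (0.59 log units; beyond the scatter) on going from an aromatic group to tert-butyl, which means higher toxicity in this test. Against the two thiophene compounds the same place gives an at least 4.6-fold lower number from compound 1 to compound 4 (0.66 log units; beyond the scatter) and an at least 4.6-fold lower number from compound 2 to compound 4 (0.66 log units; beyond the scatter) as well, so tert-butyl, the only group here without a ring, stands apart from phenyl, thiophen-2-yl and 5-bromothiophen-2-yl, and compound 4 holds the lowest number of the four. The last two steps are floors and not sizes, because compound 1 and compound 2 carry limits and not numbers: the limit of > 300000 nM in this assay, at which 2 of the 4 values shown sit.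

The compounds shown do not separate the loss of the ring from the tert-butyl group itself, a question that a methyl group, a longer chain such as n-butyl or a cyclohexyl ring at this place would address. Also open, going by these compounds, is whether an amine or a carboxylic acid here, or a change to the benzoyl or 4-chlorophenyl group, would shift the number in the same direction.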